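Urea and amide variants on a shared core: next step

The compounds below may be only part of what the source reports. "The series", "measured", "known", "first", "only" and "open" are said of these compounds alone.

Measured in a functional assay on HT-29 cells (Homo sapiens) for antiproliferative activity, read by sulforhodamine B assay, with a stated time of 48 h; on this read-out lower numbers stand for stronger inhibition and higher numbers for weaker inhibition:
- compound 1, `CCCC(=O)Nc1ccc(S(=O)(=O)Oc2ccccc2C(C)C)cc1`: 4900 nM
- compound 2, `CC(C)c1ccccc1OS(=O)(=O)c1ccc(NC(=O)NCCCCl)cc1`: 6900 nM
- compound 3, `CC(C)c1ccccc1OS(=O)(=O)c1ccc(NC(=O)NC2CCCC2)cc1`: 7400 nM

Compound 3 sits within the scatter of both neighbours: a 1.5-fold higher number from compound 1 to compound 3 (0.18 log units; within the scatter) and a 1.1-fold higher number from compound 2 to compound 3 (0.03 log units; within the scatter). Every exchange on the carbonyl carbon or on the amide-type nitrogen so far has stayed inside the scatter, including a 1.4-fold higher number from compound 1 to compound 2 (0.15 log units; within the scatter).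

Compound 4, `CC(C)c1ccccc1OS(=O)(=O)c1ccc(NC(=O)NCC2CCCC2)cc1`, carries the change (cyclopentylmethyl in place of cyclopentyl on an amide-type nitrogen). The step that bears most directly on it is the earlier exchange on the same nitrogen, a 1.1-fold higher number from compound 2 to compound 3 (0.03 log units; within the scatter), which did nothing beyond the scatter; the two exchanges on the carbonyl carbon were likewise flat. Among the measured compounds shown here, with only one step on this nitrogen and no other homologation in the set, no movement beyond the scatter is expected in this assay for compound 4, and the step from compound 3 is expected as a 1.1-fold lower number from compound 3 to compound 4 (0.02 log units; within the scatter).

Compound 4 is therefore estimated at 7000 nM in this assay, with a range from 3500 nM to 14000 nM.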

Compound 4, half-maximal inhibitory concentration: 6800 nM
Compound 4: the middle estimate sits 1.0-fold (0.01 log units) above what was measured; low and high end bracket the measured number.
By their numbers in this assay, from the lowest: compounds 1, 4, 2 and 3 (each within the scatter of the next).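

Cyclopentylmethyl in place of cyclopentyl on the amide-type nitrogen, the first homologation at this position, gives in this assay a 1.1-fold lower number from compound 3 to compound 4 (0.04 log units; within the scatter) and so leaves the read-out inside the scatter. The new compound also stays inside the scatter of the other two, with a 1.0-fold lower number from compound 2 to compound 4 (0.01 log units; within the scatter) and a 1.4-fold higher number from compound 1 to compound 4 (0.14 log units; within the scatter) as the steps, so the ring and its extended form are not separated from the 3-chloropropyl urea or the propyl amide. No measurement at hand offers any explanation for this flat picture.

From the compounds shown here alone, whether a primary amine, a carboxylic acid or a longer chain ending in a phenyl ring on this nitrogen would move the number beyond the scatter remains open. All four compounds carry the shared core, and what a change there would do is equally unresolved.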